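The source may report more compounds than this note shows. Statements on the series, on what has been measured and on what is new or still open speak of the compounds shown alone.

Compound 1 `Cc1cc(C(=O)c2ccc(F)cc2)ccc1OCC(=O)Nc1nc(-c2ccccc2)cs1` gives 33300 nM in a functional assay on DLA cells (Mus musculus) for cytotoxicity, read by MTT assay, with a stated time of 48 h; on this read-out lower numbers stand for stronger inhibition and higher numbers for weaker inhibition.
Compound 2 `Cc1cc(C(=O)c2cccc(Br)c2)ccc1OCC(=O)Nc1nc(-c2ccccc2)cs1` gives 23800 nM in this assay.
Compound 3 `Cc1cc(C(=O)c2ccccc2F)ccc1OCC(=O)Nc1nc(-c2ccccc2)cs1` gives 14800 nM in this assay.

Compound 3 has the lowest of the three numbers, but only its gap to compound 1 is beyond the scatter a 2.3-fold lower number from compound 1 to compound 3 (0.35 log units; beyond the scatter); its gap to compound 2 is within it a 1.6-fold lower number from compound 2 to compound 3 (0.21 log units; within the scatter). Compound 4 `Cc1cc(C(=O)c2ccccc2C)ccc1OCC(=O)Nc1nc(-c2ccccc2)cs1` differs from compound 3 in one place: methyl in place of fluoro on an aromatic carbon. Among the measured compounds shown here, none of the measured steps swaps a fluoro for a methyl at the same spot; they only move or exchange halogens on that ring, and even then the changes were small, as in a 1.4-fold lower number from compound 1 to compound 2 (0.15 log units; within the scatter). With nothing closer to go on, the step from compound 3 to compound 4 is expected to stay within the scatter a 1.0-fold higher number from compound 3 to compound 4 (0.01 log units; within the scatter). Compound 4 is therefore estimated at 15000 nM in this assay, with a likely range from 7000 nM to 35000 nM.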

Compound 4, half-maximal inhibitory concentration: 23100 nM
For compound 4 the middle estimate is 1.5-fold (0.19 log units) below the measured one; the measured number falls inside the stated range.
By their numbers in this assay, from the lowest: compounds 3, 4, 2 and 1 (each within the scatter of the next, the first and the last beyond it).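

Placed on an aromatic carbon ortho to a large group, methyl and fluoro cannot be told apart in this assay (a 1.6-fold higher number from compound 3 to compound 4 (0.19 log units; within the scatter)), which is the first direct comparison of these two groups at one spot. The 2-methylphenyl compound also cannot be separated from the other two, both against the 3-bromophenyl compound (a 1.0-fold lower number from compound 2 to compound 4 (0.01 log units; within the scatter)) and against the 4-fluorophenyl compound (a 1.4-fold lower number from compound 1 to compound 4 (0.16 log units; within the scatter)), so compound 4 lies within the scatter of all three even though compound 1 and compound 3 lie beyond it from each other. Nothing available explains these numbers.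

On these data alone, whether a methoxy group, an amine or a carboxylic acid on this same carbon would shift the number beyond the scatter remains open. So does how an unsubstituted phenyl on the carbonyl would compare.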